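A Methyl Added to a Piperidine Amide

This account rests on a few compounds, and the source may have more. Where it says the series, first, only, none or still open, it means among the compounds named here.

Compound 1 `CC(C(=O)N1CC2CC2C1)N1CCN(S(=O)(=O)c2ccc(C(C)(C)C)cc2)CC1`, compound 2 `CC(C(=O)N1CCCCCC1)N1CCN(S(=O)(=O)c2ccc(C(C)(C)C)cc2)CC1` and compound 3 `CC1CCN(C(=O)C(C)N2CCN(S(=O)(=O)c3ccc(C(C)(C)C)cc3)CC2)CC1` share one core and differ only in the ring on the amide carbonyl. In an ADME assay on HepG2 cells (Homo sapiens) for inhibition, with a stated time of 48 h (on this read-out lower numbers stand for an effect already at smaller amounts and higher numbers for an effect only at larger amounts of compound), compound 1 reaches only a limit of > 40000 nM. In this assay compound 2 likewise gives a limit of > 40000 nM. In this assay compound 3 also stops at a limit of > 40000 nM. The steps a step that the two limits leave unreadable from compound 1 to compound 2, a step that the two limits leave unreadable from compound 1 to compound 3 and a step that the two limits leave unreadable from compound 2 to compound 3 therefore cannot be sized, since all three values sit at the limit of > 40000 nM in this assay, at which 3 of the 3 values shown sit. Compound 3 thus stands at the same limit as the other two and has no number of its own.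

Compound 4 `CC(C(=O)N1CCC(C)(C)CC1)N1CCN(S(=O)(=O)c2ccc(C(C)(C)C)cc2)CC1` differs from compound 3 by methyl in place of hydrogen on a saturated ring carbon, a methyl in place of hydrogen on a saturated ring carbon, turning 4-methylpiperidin-1-yl into 4,4-dimethylpiperidin-1-yl. Among the compounds with values here, none of the measured steps carries a readable size, so no direction can be taken from them. The step that the limit leaves unreadable from compound 3 to compound 4 is therefore expected to stay within the scatter. For compound 4 in this assay a value of 60000 nM is estimated, between 20000 nM and 200000 nM, most likely reported again only as a limit.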

Compound 4, half-maximal effective concentration: > 40000 nM
Compound 4 ended at the assay's limit; the forecaster's own chance of this, stated with the estimate: 85%; the middle value lies beyond the limit too.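

Within the data shown here, the steps from compound 4 to compound 1, compound 2 and compound 3 cannot be read, so compound 4 adds no sized step in this assay. All four compounds stop at one assay limit: the limit of > 40000 nM in this assay, at which 4 of the 4 values shown sit.

The compounds shown leave open how these rings on the amide carbonyl would rank, and at what concentration any of them would give an effect.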